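The source may hold more compounds than are shown below. What is called first, only, known or untested is meant among the compounds shown, and "the series" means these compounds.

Of the compounds shown here, three sharing one core have been measured so far in a functional assay on HeLa cells (Homo sapiens) for inhibition, with a stated time of 72 h (a lower number here means that less compound is needed, a higher number that more compound is needed for the effect), and can be compared directly. Compound 1 (`COc1cc(CNCc2ccncc2)ccc1OCc1ccccc1F`) gives 5100 nM here, compound 2 (`COc1cc(CNCc2ccncc2)ccc1OCc1ccc(C(F)(F)F)cc1`) gives 2400 nM here, and compound 3 (`COc1cc(CNCc2ccncc2)ccc1OCc1ccc(Cl)c(Cl)c1`) gives 4000 nM here. Compound 3 lies within the usual scatter of both other compounds, so it cannot be ranked against either of them.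

Compound 4 (`COc1cc(CNCc2ccncc2)ccc1OCc1ccc([N+](=O)[O-])cc1`) differs from compound 3 in one place, on a saturated chain carbon bound to an oxygen on an aromatic ring, where 4-nitrophenyl stands in place of 3,4-dichlorophenyl (4-nitrophenyl in place of 3,4-dichlorophenyl on a saturated chain carbon bound to an oxygen on an aromatic ring). For the measured compounds named here, no measured compound carries 4-nitrophenyl, so the data give no firm direction. Because of a 1.3-fold lower number from compound 1 to compound 3 (0.11 log units; within the scatter) with 3,4-dichlorophenyl in place of 2-fluorophenyl at this same place, no step beyond the scatter is expected in this assay for the new group. The estimated step is a 1.1-fold lower number from compound 3 to compound 4 (0.06 log units; within the scatter) and its direction remains uncertain. The expected value for compound 4 is 3500 nM with an estimated range from 1500 nM to 8000 nM in this measurement.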

Compound 4, half-maximal effective concentration: 440 nM
Beside the measured number, compound 4's estimate is 8.0-fold (0.90 log units) above it; the measured number lies below the stated range.
By their numbers in this assay, from the lowest: compound 4; then compounds 2, 3 and 1 (each within the scatter of the next, the first and the last beyond it).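

Changing the group on a saturated chain carbon bound to an oxygen on an aromatic ring can shift the number well beyond the scatter in this assay, which the step from compound 1 to compound 3 did not show. The 4-nitrophenyl group stands apart from 3,4-dichlorophenyl (a 9.1-fold lower number from compound 3 to compound 4 (0.96 log units; beyond the scatter)) and from 2-fluorophenyl (a 12-fold lower number from compound 1 to compound 4 (1.06 log units; beyond the scatter)). The closest comparison is nitro in place of trifluoromethyl on an aromatic carbon (a 5.5-fold lower number from compound 2 to compound 4 (0.74 log units; beyond the scatter)), so the gain does not come with just any group at that ring carbon.

No measurement here explains why nitro gives this lower number. The compounds shown also leave open whether a nitrile, a carboxylic acid or an amine in place of nitro would keep it.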